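The source may hold more compounds than are shown below. What is called first, only, known or untested is meant among the compounds shown, and "the series" means these compounds.

Compound 1 `CC(=O)NCc1cccc(Cn2nc(NS(=O)(=O)c3ccc(Cl)s3)c3c(O)cccc32)c1`: >= 166 ug/mL
Compound 2 `COc1cccc2c1c(NS(=O)(=O)c1ccc(Cl)s1)nn2Cc1cccc(CNC(=O)C2CCOCC2)c1`: >= 193 ug/mL

In a physicochemical assay for solubility, read by chemiluminescence, measured as kinetic solubility (a higher number here means a more soluble compound, a lower number a less soluble compound), compound 2 gives >= 193 ug/mL, which is a limit of the assay and not a number. Compound 1 gives >= 166 ug/mL, which is also a limit. Compound 3 `COc1cccc2c1c(NS(=O)(=O)c1ccc(Cl)s1)nn2Cc1cccc(CNC(=O)[C@@H]2CCCCN2)c1` keeps the rest of compound 2 but has piperidin-2-yl in place of oxan-4-yl on a carbonyl carbon. Going by the values given here, no measured step shows what this change does, so the expectation rests only on the limit of compound 2 at >= 193 ug/mL. The expected change, an at least 1.0-fold lower number from compound 2 to compound 3 (0.00 log units; that floor lies within the scatter), is none beyond the scatter. For compound 3 the estimated value is 190 ug/mL, with an expected range of 120 ug/mL to 260 ug/mL.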

Compound 3, solubility: >= 220 ug/mL
Compound 3 gave a limit, no number; the forecaster's own chance of this, stated with the estimate: 60%; middle value at least 1.1-fold (0.06 log units) away from the limit.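

Compound 2 and compound 3 each give only a limit of the assay, not a number, and no step can be read between them. Going by these compounds, whether piperidin-2-yl in place of oxan-4-yl on a carbonyl carbon changes solubility, and by how much, stays open.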